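The source may report more compounds than this note shows. Statements on the series, on what has been measured and on what is new or still open speak of the compounds shown alone.

Measured compounds:
- compound 1 `O=C(O)CC[C@H](NC(=O)CN(c1nc(Cl)nc2[nH]cnc12)C1CC1)C(=O)O`: 33.3%
- compound 2 `C[C@@H](O)[C@H](NC(=O)CN(c1ncnc2c1ncn2C1CCCCO1)C1CC1)C(=O)OCc1ccccc1`: 28.4%

Two compounds have a number in a functional assay on the whole organism (Tail, strain ICR) with Mus musculus as the target, in the tail flick test, with a stated time of 60 min, at a dose of 25 umol/kg by the oral route; on this read-out higher numbers stand for a stronger effect at the one dose given and lower numbers for a weaker effect. Compound 1 gives 33.3% in this assay. Compound 2 gives 28.4% in this assay, the lower of the two numbers, with compound 1 the nearest to it, a gap that lies within the scatter of repeated measurements, so the two cannot be placed in any order.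

The step that follows leads from compound 2 to compound 3 `CSCC[C@H](NC(=O)CN(c1ncnc2c1ncn2C1CCCCO1)C1CC1)C(=O)OCc1ccccc1`, which has not yet been measured in this assay. The change is this: 2-(methylsulfanyl)ethyl in place of 1-hydroxyethyl on a saturated chain carbon bound to an amide-type nitrogen and a carbonyl carbon. No step between two measured compounds is shown that would tell how much such a swap moves the read-out in this assay, so the size of the step must be judged from compound 2 alone and from the smallness of the change in the side chain.

The expectation for compound 3 is a step from compound 2 that stays within the scatter, a number 1.6 percentage points higher from compound 2 to compound 3 (within the scatter), with no clear direction. On that basis compound 3 is estimated at 30% in this assay, in a range from 15% to 45%.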

Compound 3, a percentage reported as activity, at one dose (the size of the read-out at that dose, not a potency): 41%
The estimate for compound 3 lay 11 percentage points below the measured number, within the range that was stated.
By their numbers in this assay, from the lowest: compounds 2, 1 and 3 (each within the scatter of the next, the first and the last beyond it).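

In this assay, putting 2-(methylsulfanyl)ethyl in place of 1-hydroxyethyl on a saturated chain carbon bound to an amide-type nitrogen and a carbonyl carbon gives a number 12.6 percentage points higher from compound 2 to compound 3 (beyond the scatter), the first step shown between compounds that differ in one place. The read-out therefore responds to a change at this position, which compound 1 and compound 2 alone could not show, since their numbers lie within the scatter of each other and their structures differ in more than one place. The swap removes the hydrogen-bond donor and the defined stereocentre of 1-hydroxyethyl and brings in sulfur, but nothing available here ties the step to any one of these differences or explains it.

The compounds shown leave open whether the sulfur atom, the longer chain or the loss of the hydroxyl goes with the higher number, a question that a 2-methoxyethyl or an n-butyl group at the same place would help to separate. They also leave open how far the read-out would move with a longer chain or with an amine at the end of the chain.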